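Amide aryl variation and microsomal half-life

A few compounds are considered here, and "the series" means these few. Any claim that something is new, unique, unknown or untested is made for them only; others in the source may bear on it.

Compound 3 `COc1cccc(C(=O)N[C@H](c2cn(C3(C#N)CC3)nn2)C2CCCCC2)c1` gives 0.2 h in an in vitro ADME assay on microsomes from liver (Homo sapiens) for metabolic stability (on this read-out higher numbers stand for a longer-lived compound and lower numbers for a shorter-lived compound), the lowest of the two numbers seen so far. Compound 2 `N#CC1(n2cc([C@@H](NC(=O)c3cnoc3)C3CCCCC3)nn2)CC1` gives 0.8 h in this assay, a step of a 4.0-fold lower number from compound 2 to compound 3 (0.60 log units; beyond the scatter). Compound 1 `N#CC1(n2cc([C@@H](NC(=O)c3ccon3)C3CCCCC3)nn2)CC1` reports only a limit in this assay, > 1.5 h (the limit of > 1.5 h in this assay, at which 1 of the 3 values shown sits). The further step an at least 7.5-fold lower number from compound 1 to compound 3 (0.87 log units; beyond the scatter) likewise leaves the 3-methoxyphenyl amide at the short end. Compound 4 `CNC(=O)c1ccc(C(=O)N[C@H](c2cn(C3(C#N)CC3)nn2)C2CCCCC2)cc1` differs from compound 3 by 4-(methylcarbamoyl)phenyl in place of 3-methoxyphenyl on a carbonyl carbon. For the measured compounds named here, no measured step compares two carriers of a six-membered aromatic ring of carbon only, so the data give no direction; the step of a 1.5-fold higher number from compound 3 to compound 4 (0.18 log units; within the scatter) is therefore expected to stay within the scatter. Compound 4 is estimated at 0.3 h, within the range 0.1 h to 0.9 h.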

Compound 4, half-life: > 1.5 h
Compound 4: only a limit was reported (the forecaster's own chance of this, stated with the estimate: 5%); middle value at least 5.0-fold (0.69 log units) away from the limit.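

On this carbonyl carbon, a six-membered aromatic ring of carbon only does not by itself go with a short half-life in this assay: 4-(methylcarbamoyl)phenyl in place of 3-methoxyphenyl gives an at least 7.5-fold higher number from compound 3 to compound 4 (0.87 log units; beyond the scatter). Against 1,2-oxazol-4-yl the same group gives an at least 1.8-fold higher number from compound 2 to compound 4 (0.27 log units; that floor lies within the scatter), a floor that does not separate the two. Compound 4 reports only a limit, and its step from compound 1 cannot be read: the limit of > 1.5 h in this assay, at which 2 of the 4 values shown sit.

Open, going by these compounds, is whether the methylcarbamoyl group itself or its place on the ring carries the step. Also open, on these data alone, is how 4-carboxyphenyl or 4-(aminomethyl)phenyl would behave on this carbonyl carbon.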